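The source may report more compounds than this note shows. Statements on the series, on what has been measured and on what is new or still open speak of the compounds shown alone.

Compound 1 `CC(C)n1c(/C=C2\SC(=O)N(CC(=O)N3CCOCC3)C2=O)nc2ccccc21` gives > 50000 nM in a functional assay on A549 cells (Homo sapiens) for inhibition, read by MTT assay, with a stated time of 48 h (a higher number here means a weaker inhibitor, a lower number a stronger inhibitor), a limit and not a number.
Compound 2 `CC(C)n1c(/C=C2\SC(=O)N(CC(=O)N3CCCC3)C2=O)nc2ccccc21` gives > 50000 nM, also a limit.
Compound 3 `CC(C)n1c(/C=C2\SC(=O)N(CC(=O)N3CCCCC3)C2=O)nc2ccccc21` gives 28200 nM.

Compound 3 is the only one of these with a number and not a limit. Compound 4 `CC(C)n1c(/C=C2\SC(=O)N(CC(=O)Nc3cc(C(C)(C)C)on3)C2=O)nc2ccccc21` changes it at the same carbonyl carbon as before: (5-(tert-butyl)-1,2-oxazol-3-yl)amino in place of piperidin-1-yl on a carbonyl carbon. Going by the values given here, two measured steps bear on this: an at least 1.7-fold lower number from compound 1 to compound 3 (0.24 log units; that floor lies within the scatter) and an at least 1.7-fold lower number from compound 2 to compound 3 (0.24 log units; that floor lies within the scatter). Both exchange one saturated ring for another, so they are a weak guide to an aromatic amide of this kind. A modest move to a lower number in this assay is expected, with wide uncertainty, starting from compound 3 at 28200 nM. The estimated step is a 2.0-fold lower number from compound 3 to compound 4 (0.30 log units; within the scatter). For compound 4 the estimate is 14000 nM, with an expected range from 3000 nM to 50000 nM.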

Compound 4, half-maximal inhibitory concentration: > 50000 nM
Compound 4: no number, only a limit (the forecaster's own chance of this, stated with the estimate: 25%); middle value at least 3.5-fold (0.55 log units) from the limit.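

The only aromatic amine shown on this carbonyl carbon, (5-(tert-butyl)-1,2-oxazol-3-yl)amino, brings no gain over piperidin-1-yl in this assay, with an at least 1.7-fold higher number from compound 3 to compound 4 (0.24 log units; that floor lies within the scatter). The steps to compound 4 from compound 1 and from compound 2 cannot be read, as both ends are limits. Compound 3 remains the only compound with a number, so what can be read at this position is bounded: the limit of > 50000 nM in this assay, at which 3 of the 4 values shown sit.

As far as these compounds go, whether a 4-methylpiperidin-1-yl or a phenylamino group on this carbonyl carbon would give a number in this assay stays open. So does the part played by the tert-butyl group in compound 4.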